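This account rests on a few compounds, and the source may have more. Where it says the series, first, only, none or still open, it means among the compounds named here.

Compound 2, `CCC1(Cc2ccccc2)OS(=O)(=O)C=C1OCc1ccc(Cl)cc1`, stands in an ADME assay on HEL cells (Homo sapiens) for cytotoxicity, with a stated time of 3 days (on this read-out lower numbers stand for higher toxicity in this test and higher numbers for lower toxicity in this test), at a limit of the assay: it gives >= 50000 nM. Compound 1, `CCC1(Cc2ccccc2)OS(=O)(=O)C=C1OCC#N`, also sits at a limit and gives > 400000 nM in this assay. The step that the two limits leave unreadable from compound 1 to compound 2 cannot be read from two limits. Compound 3 is `CCC1(Cc2ccccc2)OS(=O)(=O)C=C1OCc1ccc(Br)cc1`; the change from compound 2 is bromo in place of chloro on an aromatic carbon. For the measured compounds named here, no measured step shows a bromo for chloro exchange, and the single step known is unreadable, so no shift beyond the scatter is expected: compound 3 is estimated at 80000 nM, within 30000 nM to 300000 nM, an expected step that the limit leaves unreadable from compound 2 to compound 3.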

Compound 3, minimum cytotoxic concentration: 80000 nM
Beside the measured number, compound 3's estimate shows no gap at the digits printed; the range from low to high includes it.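

In this assay, for the compounds shown here, compound 3 gives the first value in this set that is not a limit, so the exchange at this position can now be sized. Putting 4-bromophenyl in place of cyano gives an at least 5.0-fold lower number from compound 1 to compound 3 (0.69 log units; beyond the scatter), which points to higher toxicity in this test for this aryl group than for the nitrile. On these data alone, the other steps cannot be read, so the effect of bromo in place of chloro remains unknown.

As far as these compounds go, it also remains open how an amine or a carboxylic acid on this aromatic carbon would read here.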